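Hydroquinone to quinone on the shared pyrazole core

The source may report more compounds than this note shows. Statements on the series, on what has been measured and on what is new or still open speak of the compounds shown alone.

Measured so far:
compound 1 `Oc1ccc(O)c(-c2cc(-c3ccc(Cl)cc3)nn2-c2ccccc2)c1` — 9250 nM
compound 2 `NS(=O)(=O)c1ccc(-n2nc(-c3ccc(Cl)cc3)cc2-c2cc(O)ccc2O)cc1` — 16700 nM

Both were read in a functional assay on cells (Cancer cell lines, Homo sapiens) for cytotoxicity, read by sulforhodamine B assay, with a stated time of 48 h; a lower number here means a stronger inhibitor of growth, a higher number a weaker inhibitor of growth. Compound 1 has the lowest of the two numbers; its nearest neighbour is compound 2, and the step of a 1.8-fold higher number from compound 1 to compound 2 (0.26 log units; within the scatter) lies within the scatter, so the two cannot be ordered on these data.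

Compound 3 `O=C1C=CC(=O)C(c2cc(-c3ccc(Cl)cc3)nn2-c2ccccc2)=C1` is not yet measured. It differs from compound 1 in one place: a group of 8 heavy atoms (6 carbon, 2 oxygen; one six-membered non-aromatic ring of carbon only) in place of a group of 8 heavy atoms (6 carbon, 2 oxygen; one six-membered aromatic ring of carbon only), on an aromatic carbon. For the measured compounds named here, no measured step touches this part of the molecule; the only step on record, the one from compound 1 to compound 2, changes the phenyl on the ring nitrogen and was within the scatter, so it gives no guide to the size or direction of the present change. The expectation for compound 3 therefore rests on compound 1 alone, with a wide range.

Compound 3 is expected to give about 6500 nM in this assay, between 1500 nM and 28000 nM. The step this estimate means is a 1.4-fold lower number from compound 1 to compound 3 (0.15 log units; within the scatter), which is not expected to be distinguishable from the scatter.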

Compound 3, concentration for 50% growth inhibition: 51500 nM
Beside the measured number, compound 3's estimate is 7.9-fold (0.90 log units) below it; the whole stated range lies below it.
By their numbers in this assay, from the lowest: compounds 1 and 2 (each within the scatter of the next); then compound 3.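

In this assay, for the compounds shown here, the position next to the ring nitrogen that carries the 2,5-dihydroxyphenyl group is the first to show a change beyond the scatter: a 5.6-fold higher number from compound 1 to compound 3 (0.75 log units; beyond the scatter), whereas the sulfamoyl change in compound 2 stayed within it. The exchange leaves the count of heavy atoms, carbon and oxygen unchanged, but the ring is no longer aromatic and the hydrogen-bond donors go from 2 to 0, so the result is tied to this particular pair of groups and not to the size of the group. These differences all arrive together in this single pair, and no supporting measurement is available to explain the step.

From the compounds shown here alone, it remains open whether the higher number follows the loss of the hydroxyl groups or the loss of the aromatic ring, a question that a methoxy group in place of either hydroxyl, with the aromatic ring kept, could help to separate. Going by these compounds, it is also open whether the same exchange would give a step of similar size on the sulfamoyl-bearing compound 2.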